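A few compounds are considered here, and "the series" means these few. Any claim that something is new, unique, unknown or untested is made for them only; others in the source may bear on it.

Measured in a functional assay on DU-145 cells (Homo sapiens) for cytotoxicity, read by MTT assay, with a stated time of 24 h; a lower number here means a stronger inhibitor, a higher number a weaker inhibitor:
Compound 1 `COc1ccc(/C=C2\CN(C(=S)SCc3cn(Cc4ccccc4F)nn3)C/C(=C\c3ccc(OC)cc3)C2=O)cc1` gives 54500 nM here
Compound 2 `COc1ccc(/C=C2\CN(Cc3cn(Cc4cccc(Cl)c4)nn3)C/C(=C\c3ccc(OC)cc3)C2=O)cc1` gives 15400 nM here
Compound 3 `Cc1ccc(/C=C2\CN(Cc3cn(Cc4ccc(F)cc4)nn3)C/C(=C\c3ccc(C)cc3)C2=O)cc1` gives 49700 nM here

Of these three, compound 1 at 54500 nM and compound 3 at 49700 nM lie within the scatter of each other. Compound 2 at 15400 nM sits beyond the scatter from compound 1 and is the stronger inhibitor of that pair.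

Compound 4 `COc1ccc(/C=C2\CN(C(=S)SCc3cn(Cc4ccccc4Cl)nn3)C/C(=C\c3ccc(OC)cc3)C2=O)cc1` departs from compound 1 at a single place: chloro in place of fluoro on an aromatic carbon, ortho to a large group, so that 2-fluorobenzyl becomes 2-chlorobenzyl. Among the compounds with values here, no measured pair here shows this change on its own, so the data offer no direct guide to its size. In this assay no step beyond the scatter is expected, and any direction is uncertain. The estimated step of a 1.2-fold lower number from compound 1 to compound 4 (0.08 log units; within the scatter) is expected to stay within the scatter. The estimate for compound 4 is 45000 nM, with the expected range running from 20000 nM to 100000 nM.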

Compound 4, half-maximal inhibitory concentration: > 80000 nM
Compound 4: a limit, no number; the forecaster's own chance of this, stated with the estimate: 10%; middle value at least 1.7-fold (0.24 log units) away from the limit.
By their numbers in this assay, from the lowest: compound 2; then compounds 3 and 1 (each within the scatter of the next). At a limit, above all of these: compound 4.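

In this assay, compound 4 gives a limit and not a number: the limit of > 80000 nM in this assay, at which 1 of the 4 values shown sits. Exchanging 2-fluorobenzyl for 2-chlorobenzyl on the shared core gives an at least 1.4-fold higher number from compound 1 to compound 4 (0.16 log units; that floor lies within the scatter), a step known only by its floor. This first reading at this place, ortho to a large group, shows that chloro in place of fluoro brings no gain in strength, though the limit leaves unsettled how far compound 4 really lies from compound 1.

The compounds shown leave open whether a methoxy group, a nitrile or a plain unsubstituted benzyl would lower the number at this place. They also leave open whether the same exchange of fluoro for chloro would behave alike on a core carrying a different link to the triazole-bearing side chain.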